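A few compounds are considered here, and "the series" means these few. Any claim that something is new, unique, unknown or untested is made for them only; others in the source may bear on it.

The measured compounds are:
compound 1, `C1=C(c2cccnc2)C[C@@H]2CNC[C@H]1C2`, with 111% in an in vitro functional assay on SH-EP1 cells for agonist activity at Neuronal acetylcholine receptor; alpha4/beta2 (Homo sapiens), read by FLIPR and calcium flux; a lower number here means a smaller maximal response, a higher number a larger maximal response;
compound 2, `CN1C[C@@H]2C=C(c3cccnc3)C[C@@H](C2)C1`, with 53% in this assay;
compound 3, `CC(C)Oc1cncc(C2=CC3CNCC(C2)C3)c1`, with 75% in this assay.

Compound 1 and compound 2 differ in one place only, (methyl in place of hydrogen on an amine nitrogen in a ring), and this change brought a number 58 percentage points lower from compound 1 to compound 2 (beyond the scatter). Compound 3 stands second highest of the three. The difference between the core of compound 3 and the core of compound 1 is not broken down here. Compound 4, `CC(C)Oc1cncc(C2=CC3CC(C2)CN(C)C3)c1`, has not yet been measured in this assay; it differs from compound 3 by methyl in place of hydrogen on an amine nitrogen in a ring, the same change as that between compound 1 and compound 2, at a place described in identical terms. Compound 4 is therefore expected to show a clearly smaller maximal response than compound 3, a step of about a number 45 percentage points lower from compound 3 to compound 4 (beyond the scatter), because the earlier step was a number 58 percentage points lower from compound 1 to compound 2 (beyond the scatter). Compound 4 is estimated at 30%, most likely between 10% and 55%.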

Compound 4, largest response reached (reported as percent of maximum), in percent of the reference or control that the assay uses: 1%
Estimate against measurement, compound 4: 29 percentage points above, and the stated range ends above it.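

In this assay, methyl in place of hydrogen on an amine nitrogen in a ring gave a number 74 percentage points lower from compound 3 to compound 4 (beyond the scatter). The change lowered the maximal response on both cores, but the size of the step did not carry over unchanged from one core to the other: the same change on two cores in this assay, a number 58 percentage points lower (beyond the scatter) from compound 1 to compound 2 and a number 74 percentage points lower (beyond the scatter) from compound 3 to compound 4, 16 percentage points apart, beyond the scatter of two such steps These two pairs show neither why the steps differ in size nor that the change would act the same way on any other core in the series.

The compounds shown leave open whether an ethyl or a benzyl group on that nitrogen would lower the response as methyl does. They also leave open how the change would act on a core carrying a fluorine or an amine in place of what these cores carry.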